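The source may hold more compounds than are shown below. What is called first, only, known or untested is meant among the compounds shown, and "the series" means these compounds.

Compound 3 `Cc1ccccc1-c1ccccc1OC(C)C1=NCCN1` gives 234 nM in an assay on CHO cells for displacement of a labelled ligand from Alpha-2C adrenergic receptor (Homo sapiens) (a higher number here means a weaker inhibitor, a lower number a stronger inhibitor), and compound 1 `Cc1ccc(-c2ccccc2OC(C)C2=NCCN2)cc1` gives 251 nM, a number within the scatter of it; both give lower numbers than compound 2 `CC(Oc1ccccc1-c1ccncc1)C1=NCCN1`, which gives 1450 nM. Compound 4 `Cc1cccc(-c2ccccc2OC(C)C2=NCCN2)c1` differs from compound 3 by 3-methylphenyl in place of 2-methylphenyl on an aromatic carbon. For the measured compounds named here, the one measured step that bears on this is a 1.1-fold lower number from compound 1 to compound 3 (0.03 log units; within the scatter), a swap of one methylphenyl for another that left the number unchanged within the scatter. The steps of a 5.8-fold higher number from compound 1 to compound 2 (0.76 log units; beyond the scatter) and a 6.2-fold lower number from compound 2 to compound 3 (0.79 log units; beyond the scatter) exchange a methylphenyl for a pyridinyl and so speak to a different kind of change. For compound 4 the expected step is a 1.0-fold higher number from compound 3 to compound 4 (0.01 log units; within the scatter), none beyond the scatter. Compound 4 is therefore estimated at 240 nM, between 120 nM and 480 nM.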

Compound 4, inhibition constant: 245 nM
Compound 4: middle estimate off by 1.0-fold (0.01 log units), on the low side; low and high end bracket the measured number.
By their numbers in this assay, from the lowest: compounds 3, 4 and 1 (each within the scatter of the next); then compound 2.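

Together with the 4-methylphenyl and 2-methylphenyl compounds, the 3-methylphenyl group completes the set of methylphenyl placements at this aromatic carbon. In this assay, both a 1.0-fold higher number from compound 3 to compound 4 (0.02 log units; within the scatter) and a 1.0-fold lower number from compound 1 to compound 4 (0.01 log units; within the scatter) stay within the scatter, so moving the methyl around this ring makes no measurable difference among these compounds. By contrast, a 5.9-fold lower number from compound 2 to compound 4 (0.77 log units; beyond the scatter) lies beyond the scatter and matches what compound 1 and compound 3 show against the pyridin-4-yl group.

As far as these compounds go, whether a methoxy group, a chlorine or an aminomethyl group on this ring would leave the number equally unmoved remains open. Nothing available explains why the methyl's placement makes no measurable difference here.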